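The source may hold more compounds than are shown below. What is called first, only, known or untested is meant among the compounds shown, and "the series" means these compounds.

Values in a functional assay on HCT-116 cells (Homo sapiens) for inhibition, read by MTT assay, with a stated time of 72 h; on this read-out lower numbers stand for stronger inhibition and higher numbers for weaker inhibition:
- compound 1 `COc1cc2c(Oc3ccc(NC(=O)c4nn(-c5ccccc5C)cc(C)c4=O)cc3)ccnc2cc1OCCCCCCC(=O)NO`: 660 nM
- compound 2 `COc1cc2c(Oc3ccc(NC(=O)c4nn(-c5ccc(F)c(Cl)c5)cc(C)c4=O)cc3)ccnc2cc1OCCCCCCC(=O)NO`: 370 nM

Within the data shown here, compound 2 lies within the scatter of compound 1, the only other measured number. Compound 3 `COc1cc2c(Oc3ccc(NC(=O)c4nn(-c5ccc(C)cc5C)cc(C)c4=O)cc3)ccnc2cc1OCCCCCCC(=O)NO` carries 2,4-dimethylphenyl in place of 3-chloro-4-fluorophenyl on an aromatic nitrogen. Among the measured compounds shown here, one measured step bears on this change, at the same place: a 1.8-fold lower number from compound 1 to compound 2 (0.25 log units; within the scatter), which stayed within the scatter. No step beyond the scatter is therefore expected in this assay, and the expected step is a 1.4-fold higher number from compound 2 to compound 3 (0.13 log units; within the scatter). The estimated value for compound 3 is 500 nM, with an expected range of 220 nM to 1100 nM.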

Compound 3, half-maximal inhibitory concentration: 440 nM
The estimate for compound 3 lay 1.1-fold (0.06 log units) above the measured number; the range from low to high includes it.
By their numbers in this assay, from the lowest: compounds 2, 3 and 1 (each within the scatter of the next).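

In this assay, 2,4-dimethylphenyl in place of 3-chloro-4-fluorophenyl on the aromatic nitrogen gives a step within the scatter (a 1.2-fold higher number from compound 2 to compound 3 (0.08 log units; within the scatter)), so replacing both halogens with methyl groups at the same heavy-atom count leaves the number essentially unchanged. Methyl in place of hydrogen on an aromatic carbon of the 2-methylphenyl group also stays within the scatter (a 1.5-fold lower number from compound 1 to compound 3 (0.18 log units; within the scatter)). No measured evidence bears on why these steps are small.

As far as these compounds go, whether a pyridyl or benzyl group on this nitrogen, or an amine or carboxylic acid on the phenyl ring, would move the number beyond the scatter remains open.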